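The source may hold more compounds than are shown below. What is called first, only, known or untested is meant among the compounds shown, and "the series" means these compounds.

In a functional assay on U-251 cells (Homo sapiens) for cytotoxicity (on this read-out higher numbers stand for weaker inhibition of growth and lower numbers for stronger inhibition of growth), compound 1 (`COc1ccc(C2=C(c3ccc(SC)cc3)CC3CCCN3C2=O)cc1O`) gives 5000 nM and compound 2 (`COc1ccc(C2=C(c3ccc(SC)cc3)CC3CCCN3C2=O)cc1OC`) gives 300 nM, while compound 3 (`CSc1ccc(C2=C(c3ccc(O)c(O)c3)C(=O)N3CCCC3C2)cc1`) stands at 30000 nM as the highest number of the three and so the weakest inhibition of growth. Compound 4 (`COc1ccc(C2=C(c3ccc(SC)cc3)CC3CCCN3C2=O)cc1`) is unmeasured and carries 4-methoxyphenyl in place of 3,4-dihydroxyphenyl on a double-bonded ring carbon. Going by the values given here, two measured steps bear on this. A large step, a 17-fold lower number from compound 1 to compound 2 (1.22 log units; beyond the scatter) as methyl replaces hydrogen on an oxygen on an aromatic ring, sits beside a modest one, a 6.0-fold higher number from compound 1 to compound 3 (0.78 log units; beyond the scatter) as hydrogen replaces methyl there. Among these three compounds, more methyl goes with lower numbers, and none goes against this. Among the compounds with values here, no measured step removes a ring oxygen outright, so that part of the change is unknown. Compound 4 has no hydrogen on an oxygen, like compound 2 at 300 nM in this read-out, so a large step to a lower number is expected. The expected change is a 38-fold lower number from compound 3 to compound 4 (1.57 log units; beyond the scatter) overall. The estimate for compound 4 is 800 nM with an expected range of 150 nM to 5000 nM on this read-out.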

Compound 4, concentration for 50% growth inhibition: 2000 nM
Beside the measured number, compound 4's estimate is 2.5-fold (0.40 log units) below it, and the stated range covers the measured number.
By their numbers in this assay, from the lowest: compound 2; then compound 4; then compound 1; then compound 3.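

In this assay, the aryl group on the double-bonded ring carbon can lose one oxygen substituent outright, and the outcome depends on which one goes. Hydrogen in place of the hydroxy of compound 1 lowers the number (a 2.5-fold lower number from compound 1 to compound 4 (0.40 log units; beyond the scatter)), whereas hydrogen in place of the methoxy of compound 2 raises it (a 6.7-fold higher number from compound 2 to compound 4 (0.82 log units; beyond the scatter)), so among these three compounds hydrogen at that place falls between hydroxy and methoxy. The full exchange of 3,4-dihydroxyphenyl for 4-methoxyphenyl also lowers the number (a 15-fold lower number from compound 3 to compound 4 (1.18 log units; beyond the scatter)), which shows that a single methoxy on that ring already gives much stronger inhibition of growth than the two hydroxy groups.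

Nothing available here explains these differences. Still open, from the compounds shown here alone, is whether an ethoxy group, a fluorine or an amine at the place of the second methoxy of compound 2 would keep the number as low.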